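A Piperidine Urea in Place of the Cyclopropyl Amide

This account rests on a few compounds, and the source may have more. Where it says the series, first, only, none or still open, it means among the compounds named here.

Measured so far in an assay on HEK293 cells for positive allosteric modulation of metabotropic glutamate receptor 5 (Homo sapiens), read by FLIPR, with a stated time of 1 h; a higher number here means that more compound is needed for the effect, a lower number that less compound is needed:
compound 1, `COc1ccccc1C#Cc1nc2c(s1)C(=O)NCC2`: > 10000 nM
compound 2, `CC1CC1C(=O)N1CCc2nc(C#Cc3ccccc3)sc2C1`: 9.4 nM
compound 3, `O=S(=O)(C1CCCCC1)N1Cc2nc(C#Cc3ccccc3)sc2C1`: 150 nM

The value of compound 1 is a limit, not a number, and it sits at the limit of > 10000 nM in this assay, at which 1 of the 3 values shown sits. Among the two numbers that are known, compound 2 has the lower one, with 9.4 nM in this assay, while compound 3 gives 150 nM, a gap that is well beyond the usual scatter. Compound 2 therefore stands at the low end of what has been measured.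

The next compound, compound 4, `O=C(N1CCCCC1)N1CCc2nc(C#Cc3ccccc3)sc2C1`, keeps the shared core and the phenylethynyl group of compound 2 and changes only the group on the carbonyl carbon: piperidin-1-yl in place of 2-methylcyclopropyl on a carbonyl carbon. The carbonyl still sits on the amide-type nitrogen in the ring, so the acyl substituent becomes a (piperidin-1-yl)carbonyl in place of the (2-methylcyclopropyl)carbonyl.

Among the measured compounds shown here, no measured pair in this set follows the same change, so the size of the step has to be guessed from compound 2 alone. Compound 4 is expected to remain a numbered value rather than a limit, with a modest rise in the number; the step from compound 2 to compound 4 is estimated at a 3.2-fold higher number from compound 2 to compound 4 (0.50 log units; beyond the scatter). Compound 4 is thus expected to give about 30 nM, within a range from 8 nM to 150 nM.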

Compound 4, half-maximal effective concentration: 75 nM
Beside the measured number, compound 4's estimate is 2.5-fold (0.40 log units) below it; measured number inside the range.
By their numbers in this assay, from the lowest: compound 2; then compounds 4 and 3 (each within the scatter of the next). At a limit, above all of these: compound 1.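

In this assay, among the compounds shown here, the group on the carbonyl carbon proves to be a place where the number responds: piperidin-1-yl in place of 2-methylcyclopropyl gives an 8.0-fold higher number from compound 2 to compound 4 (0.90 log units; beyond the scatter), the first step in this set that can be read from a change in one place. Compound 4 keeps a measured number of 75 nM, even though the entering group brings a larger ring and a ring nitrogen on the carbonyl carbon, while neither group carries a hydrogen-bond donor, a hydrogen-bond acceptor or a net charge. Nothing measured in this set accounts for the size of the step.

A single step cannot tell whether the rise in the number goes with the ring nitrogen on the carbonyl carbon or with the six-membered ring as such. Cyclohexyl, dimethylamino or morpholin-4-yl on the same carbonyl carbon would separate these two readings, and how far the step carries over to a substituted phenyl ring on the alkyne remains open as well.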